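Butoxy gives way to fluoro on the shared core

The compounds below may be only part of what the source reports. "The series", "measured", "known", "first", "only" and "open" are said of these compounds alone.

In a functional assay on A549 cells (Homo sapiens) for cytotoxicity, with a stated time of 48 h (on this read-out higher numbers stand for weaker inhibition and lower numbers for stronger inhibition), compound 3 (`CCCCOc1ccc2oc(/C=C/[S+](C)[O-])cc(=O)c2c1`) gives 1400 nM and stands within the scatter of both compound 1 (`CCCCCOc1ccc2oc(/C=C/[S+](C)[O-])cc(=O)c2c1`) with 1600 nM and compound 2 (`CC(C)CC(=O)Oc1ccc2oc(/C=C/[S+](C)[O-])cc(=O)c2c1`) with 2300 nM on the same read-out. Compound 4 (`C[S+]([O-])/C=C/c1cc(=O)c2cc(F)ccc2o1`) carries fluoro in place of butoxy on an aromatic carbon. The measured steps bear on this change only in part. Butyl in place of pentyl shows a 1.1-fold lower number from compound 1 to compound 3 (0.06 log units; within the scatter) and butyl in place of isobutylcarbonyl shows a 1.6-fold lower number from compound 2 to compound 3 (0.22 log units; within the scatter) while isobutylcarbonyl in place of pentyl shows a 1.4-fold higher number from compound 1 to compound 2 (0.16 log units; within the scatter) and all of these stay within the scatter. Each of them keeps a chain on the oxygen, and none shows what happens when that oxygen and its chain are lost. The data therefore give no firm direction. In this assay the expected step is a 2.1-fold higher number from compound 3 to compound 4 (0.33 log units; beyond the scatter) and this modest rise to a higher number is a tentative expectation. Compound 4 is estimated at 3000 nM (expected range 1000 nM to 9000 nM).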

Compound 4, half-maximal inhibitory concentration: 2100 nM
Beside the measured number, compound 4's estimate is 1.4-fold (0.15 log units) above it; low and high end bracket the measured number.
By their numbers in this assay, from the lowest: compounds 3, 1, 4 and 2 (each within the scatter of the next).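

Within the data shown here, the fluoro group on this aromatic carbon removes both the oxygen and the chain, which no earlier step did, yet in this assay the change gives a 1.5-fold higher number from compound 3 to compound 4 (0.18 log units; within the scatter). The same holds against the other two oxygen-linked groups, with fluoro in place of pentyloxy giving a 1.3-fold higher number from compound 1 to compound 4 (0.12 log units; within the scatter) and fluoro in place of (isobutylcarbonyl)oxy giving a 1.1-fold lower number from compound 2 to compound 4 (0.04 log units; within the scatter). Among these four compounds, then, the position tolerates the loss of the oxygen and its chain without a change that stands clear of the scatter, and no supporting measurement is available to account for this.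

On these data alone, whether an amine, a carboxylic acid or a much longer chain on this aromatic carbon would move the number beyond the scatter remains open. So does the result with plain hydrogen there, which would show whether the position needs any substituent at all.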